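This account rests on a few compounds, and the source may have more. Where it says the series, first, only, none or still open, it means among the compounds named here.

Measured so far:
compound 1 `CCCCCCCCCCCCCCCc1cc(=O)c2c(O)cc(O)c(C)c2o1`, a functional assay on MCF7 cells (Homo sapiens) for antiproliferative activity, read by MTT assay; a lower number here means a stronger inhibitor, a higher number a weaker inhibitor: 17500 nM
compound 2 `CCCCCCCCCCCCCCCc1cc(=O)c2c(O)c(C)c(OCOC)c(C)c2o1`, this assay: > 67200 nM

Compound 1 gives 17500 nM in this assay, a weak but measurable number. Compound 2 sits at the limit of the assay: > 67200 nM is not a number, and compound 2 stands at the limit of > 67200 nM in this assay, at which 1 of the 2 values shown sits. Among the measured compounds shown here, nothing more than that is known of compound 2, so no step between the two measured compounds can be read, and the two structures differ in more than one place in any case.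

Compound 3 `CCCCCCCCCCCCCCCc1cc(=O)c2c(O)c(C)c(O)c(C)c2o1` is not yet measured. It differs from compound 2 in one place: hydrogen in place of methoxymethyl on an oxygen on an aromatic ring. For the measured compounds named here, no measured step of this kind is available. The expectation is that the step from compound 2 to compound 3 in this assay runs toward a stronger inhibitor, with compound 3 returning to a measurable value, since compound 1, which also carries a free hydroxy at that position, gives 17500 nM. The size cannot be set from the limit at which compound 2 stands. Compound 3 is estimated at 20000 nM, in the range 7000 nM to 60000 nM, an expected step of an at least 3.3-fold lower number from compound 2 to compound 3 (0.52 log units; beyond the scatter).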

Compound 3, half-maximal inhibitory concentration: > 67200 nM
Compound 3: no number, only a limit (the forecaster's own chance of this, stated with the estimate: 25%); middle value at least 3.3-fold (0.52 log units) from the limit.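

In this assay compound 3 gives > 67200 nM, which is a limit of the assay and not a number. The change from methoxymethoxy to hydroxy therefore leaves a step that cannot be read, and a hydroxy on an oxygen-bearing aromatic position does not by itself restore a measurable value in this series. Among the compounds shown here, the one readable change lies elsewhere: methyl in place of hydrogen on an aromatic carbon gives an at least 3.8-fold higher number from compound 1 to compound 3 (0.58 log units; beyond the scatter), so the difference between a measurable value and the limit follows that methyl in this pair, the only pair available for this comparison.

From the compounds shown here alone, how much weaker compound 3 is than compound 1, and whether compound 2 and compound 3 differ at all, remains hidden, as the reading of the series stops at one ceiling: the limit of > 67200 nM in this assay, at which 2 of the 3 values shown sit. Also open is whether an amine or a carboxylic acid on that aromatic carbon in place of the methyl would keep a measurable value, and whether a longer chain would shift either compound 1 or compound 3.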